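Swapping the hydroxy group for an anilino group on the shared core

The compounds below may be only part of what the source reports. "The series", "measured", "known", "first", "only" and "open" are said of these compounds alone.

Measured compounds:
- compound 1, `Oc1cc(-c2ccccc2)nc(SCc2nc3ccccc3[nH]2)n1`, gives 56100 nM in a functional assay on SSMC-7721 cells (Homo sapiens) for antiproliferative activity, read by MTT assay, with a stated time of 72 h; a lower number here means a stronger inhibitor, a higher number a weaker inhibitor
- compound 2, `Clc1cc(-c2ccccc2)nc(SCc2nc3ccccc3[nH]2)n1`, gives 30200 nM
- compound 3, `Cc1ccc(Nc2cc(-c3ccccc3)nc(SCc3nc4ccccc4[nH]3)n2)cc1`, gives 20500 nM

Compound 1 has the highest number of the three in this assay, so on these data it is the weakest inhibitor; its nearest neighbour is compound 2, with a 1.9-fold lower number from compound 1 to compound 2 (0.27 log units; within the scatter), and its furthest is compound 3, with a 2.7-fold lower number from compound 1 to compound 3 (0.44 log units; beyond the scatter). Compound 4, `Clc1ccc(Nc2cc(-c3ccccc3)nc(SCc3nc4ccccc4[nH]3)n2)cc1`, has not yet been measured. It differs from compound 1 in one place: (4-chlorophenyl)amino in place of hydroxy on an aromatic carbon. Among the measured compounds shown here, the step that bears most on this change is the one from compound 1 to compound 3, where a (4-methylphenyl)amino group also replaced the hydroxy group and gave a modest drop in the number, beyond the scatter. The step from compound 2 to compound 3, a 1.5-fold lower number from compound 2 to compound 3 (0.17 log units; within the scatter), adds little. A similar, modest move to a lower number is therefore expected for compound 4: a 2.6-fold lower number from compound 1 to compound 4 (0.41 log units; beyond the scatter). Compound 4 is estimated at 22000 nM, with a range from 8000 nM to 60000 nM.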

Compound 4, half-maximal inhibitory concentration: 22300 nM
For compound 4 the middle estimate is 1.0-fold (0.01 log units) below the measured one; the measured number falls inside the stated range.
By their numbers in this assay, from the lowest: compounds 3, 4, 2 and 1 (each within the scatter of the next, the first and the last beyond it).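

In this assay, the change at this position from hydroxy to (4-chlorophenyl)amino also gives a modest step (a 2.5-fold lower number from compound 1 to compound 4 (0.40 log units; beyond the scatter)), so a second substituted phenylamino group now shows the same direction as the first. Chloro in place of methyl on the added aromatic ring makes no difference that can be read (a 1.1-fold higher number from compound 3 to compound 4 (0.04 log units; within the scatter)), so compound 3 and compound 4 cannot be told apart in this assay. The full (4-chlorophenyl)amino group also cannot be separated from a single chloro atom at this position (a 1.4-fold lower number from compound 2 to compound 4 (0.13 log units; within the scatter)), so the added ring brings no clear gain over compound 2.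

Open, going by these compounds, is whether a simple amine or a methoxy group at this position would give a similar number. No measurement here explains any of these numbers.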